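The source may hold more compounds than are shown below. What is called first, only, known or untested is meant among the compounds shown, and "the series" means these compounds.

Three compounds built on one shared core have been examined in a functional assay on RAW264.7 cells (Mus musculus) for inhibition, read by Griess assay, with stated times of 2 h and 24 h; on this read-out higher numbers stand for weaker inhibition and lower numbers for stronger inhibition. Compound 1 `CCn1cc(COc2cc(O)c3c(c2)O[C@H](c2ccc(OC)c(O)c2)CC3=O)nn1` carries a methyl on the saturated chain carbon bound to an aromatic nitrogen, and in this assay compound 1 gives 15000 nM. Compound 2 `COc1ccc([C@@H]2CC(=O)c3c(O)cc(OCc4cn(Cc5cccc(Cl)c5)nn4)cc3O2)cc1O` bears a 3-chlorophenyl at that carbon, and compound 2 gives 18200 nM. Compound 3 `COc1ccc([C@@H]2CC(=O)c3c(O)cc(OCc4cn(Cc5ccc(C(F)(F)F)cc5)nn4)cc3O2)cc1O` bears a 4-(trifluoromethyl)phenyl there, and compound 3 gives 17700 nM, the second highest of the three numbers, though every gap among them is within the scatter: a 1.2-fold higher number from compound 1 to compound 2 (0.08 log units; within the scatter), a 1.2-fold higher number from compound 1 to compound 3 (0.07 log units; within the scatter) and a 1.0-fold lower number from compound 2 to compound 3 (0.01 log units; within the scatter).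

Compound 4 `COc1ccc([C@@H]2CC(=O)c3c(O)cc(OCc4cn(C5CCC5)nn4)cc3O2)cc1O` differs from compound 3 in one place: cyclobutyl in place of 4-(trifluoromethyl)benzyl on an aromatic nitrogen. Within the data shown here, no measured step exchanges a benzyl group for a cyclobutyl on that nitrogen. Among the measured compounds shown here, the steps that bear on the change are the three already seen at the aromatic nitrogen, where methyl, 3-chlorophenyl and 4-(trifluoromethyl)phenyl on the saturated chain carbon all returned numbers within the scatter of one another. On this evidence the group carried by the aromatic nitrogen has not moved the number, so no step beyond the scatter is expected: a 1.1-fold lower number from compound 3 to compound 4 (0.04 log units; within the scatter). Compound 4 is therefore estimated at 16000 nM, with a range from 7000 nM to 36000 nM.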

Compound 4, half-maximal inhibitory concentration: 15300 nM
For compound 4 the middle estimate is 1.0-fold (0.02 log units) above the measured one; the measured number falls inside the stated range.
By their numbers in this assay, from the lowest: compounds 1, 4, 3 and 2 (each within the scatter of the next).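

The earlier compounds shown here all kept an open saturated chain carbon on the aromatic nitrogen, whereas compound 4 places a four-membered non-aromatic ring of carbon only there, and it also drops from 11 heavy atoms to 4 relative to the 4-(trifluoromethyl)benzyl group. In this assay this exchange gives no step beyond the scatter against any earlier compound: the cyclobutyl in place of 4-(trifluoromethyl)benzyl gives (a 1.2-fold lower number from compound 3 to compound 4 (0.06 log units; within the scatter)), in place of 3-chlorobenzyl it gives (a 1.2-fold lower number from compound 2 to compound 4 (0.08 log units; within the scatter)), and in place of ethyl it gives (a 1.0-fold higher number from compound 1 to compound 4 (0.01 log units; within the scatter)). The insensitivity at this position thus now extends to a ring of carbon on the nitrogen and to groups of quite different size among these four compounds, but no measurement shown explains it.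

Every group shown on this nitrogen is a hydrocarbon, or a benzyl carrying chlorine or trifluoromethyl, so whether an amine or a carboxylic acid on a longer chain there would give a number beyond the scatter remains open. As far as these compounds go, whether any change elsewhere on the shared core would move the number also remains open, since all four compounds share that core unchanged.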